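Trimming the phenoxy chain in a hydroxamic acid pair

The source may report more compounds than this note shows. Statements on the series, on what has been measured and on what is new or still open speak of the compounds shown alone.

Compound 1 `Cc1ccc(-c2cnc(N(Cc3ccccc3)Cc3ccc(C(=O)NO)cc3)s2)cc1` gives 4410 nM
Compound 2 `Cc1ccc(-c2cnc(N(CCCCOc3ccccc3)Cc3ccc(C(=O)NO)cc3)s2)cc1` gives 14200 nM

In a functional assay on A549 cells (Homo sapiens) for antiproliferative activity, read by MTT assay, with a stated time of 48 h (on this read-out lower numbers stand for stronger inhibition of growth and higher numbers for weaker inhibition of growth), compound 2 at 14200 nM stands highest of the two numbers. Compound 3 `Cc1ccc(-c2cnc(N(CCCOc3ccccc3)Cc3ccc(C(=O)NO)cc3)s2)cc1` has phenoxy in place of phenoxymethyl on a saturated chain carbon, three bonds along the chain from a nitrogen on an aromatic ring, which turns 4-phenoxybutyl into 3-phenoxypropyl. Going by the values given here, the one measured step bearing on this is modest and beyond the scatter, a 3.2-fold higher number from compound 1 to compound 2 (0.51 log units; beyond the scatter), and it came with the longer chain. A smaller move towards lower numbers is therefore expected in this assay, an estimated 1.6-fold lower number from compound 2 to compound 3 (0.20 log units; within the scatter). Compound 3 is estimated at 9000 nM, within an expected range of 4000 nM to 20000 nM.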

Compound 3, concentration for 50% growth inhibition: 2530 nM
The estimate for compound 3 lay 3.6-fold (0.55 log units) above the measured number, outside the stated range (below it).
By their numbers in this assay, from the lowest: compounds 3 and 1 (each within the scatter of the next); then compound 2.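

In this assay, shortening 4-phenoxybutyl to 3-phenoxypropyl gave a clear change (a 5.6-fold lower number from compound 2 to compound 3 (0.75 log units; beyond the scatter)), showing that chain length alone moves the number at this position, which the earlier pair could not separate from the swap of the whole group. With 2-phenoxyethyl in place of phenyl, the phenoxy-ended chain of compound 3 stands apart from nothing (a 1.7-fold lower number from compound 1 to compound 3 (0.24 log units; within the scatter)). Nothing measured here accounts for this sensitivity to length. Left open is how a still shorter 2-phenoxyethyl chain would read, and whether an amine in place of the phenoxy at the chain end would hold the number of compound 3.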